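A few compounds are considered here, and "the series" means these few. Any claim that something is new, unique, unknown or untested is made for them only; others in the source may bear on it.

The three compounds share a hydrazone core built from a diiodinated phenol and a benzoyl hydrazide, and they differ only in where the phenol oxygen sits and whether the benzoyl ring carries a methoxy. Compound 1 `O=C(N/N=C/c1cc(I)cc(I)c1O)c1ccccc1` in a functional assay on HepG2 cells (Homo sapiens) for cytotoxicity, with a stated time of 24 h (a higher number here means a weaker inhibitor, a lower number a stronger inhibitor), gives only a limit of the assay, > 50000 nM. Compound 2 `COc1ccc(C(=O)N/N=C/c2cc(I)cc(I)c2O)cc1` in this assay gives 45200 nM. Compound 3 `O=C(N/N=C/c1cc(I)c(O)c(I)c1)c1ccccc1` in this assay gives 191000 nM, which is the highest of the two numbers that are not limits, and the nearest to it is compound 2, whose number is lower by a gap that lies beyond the scatter.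

Compound 4 `COc1ccc(C(=O)N/N=C/c2cc(I)c(O)c(I)c2)cc1` differs from compound 3 by methoxy in place of hydrogen on an aromatic carbon. Among the measured compounds shown here, the one measured step of this kind is an at least 1.1-fold lower number from compound 1 to compound 2 (0.04 log units; that floor lies within the scatter), and it rests on (the limit of > 50000 nM in this assay, at which 1 of the 3 values shown sits), so it tells only that the methoxy did not raise the number there. Applied to compound 3, the same change is expected to bring a step of a 1.3-fold lower number from compound 3 to compound 4 (0.10 log units; within the scatter) in this assay, no larger than the scatter and, if anything, toward a lower number. Compound 4 is therefore estimated to give 150000 nM in this assay, with a range from 50000 nM to 400000 nM.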

Compound 4, half-maximal inhibitory concentration: > 100000 nM
Compound 4: no number, only a limit (the forecaster's own chance of this, stated with the estimate: 15%); the middle value lies beyond the limit too.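

Compound 4 gives > 100000 nM in this assay and that value is only a limit, so the step from compound 3 to compound 4 cannot be read: the limit of > 100000 nM in this assay, at which 1 of the 4 values shown sits.

The compounds shown leave open how far, and in which direction, methoxy in place of hydrogen on an aromatic carbon moves the number when the phenol oxygen sits as in compound 3.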